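This account rests on a few compounds, and the source may have more. Where it says the series, first, only, none or still open, it means among the compounds named here.

Measured compounds:
- compound 1 `c1ccc(Nc2cccc(-c3nc4ccccc4s3)c2)nc1`: 13000 nM
- compound 2 `CCn1c(=O)/c(=C2\Sc3ccccc3N2C)s/c1=C\c1ccncc1Nc1ccccc1F`: 330 nM
- compound 3 `c1ccc(Nc2nc(-c3nc4ccccc4s3)cs2)cc1`: 7600 nM

In a functional assay on MCF7 cells (Homo sapiens) for inhibition (on this read-out lower numbers stand for stronger inhibition and higher numbers for weaker inhibition), compound 2 gives the lowest number of the three measured compounds; compound 3 stands nearest to it, with a higher number beyond the scatter, and compound 1 stands furthest, also beyond the scatter. Compound 4 `CCn1c(=O)/c(=C2\Sc3ccccc3N2C)s/c1=C\c1ccncc1Nc1ccccc1Cl` is not yet measured. It differs from compound 2 in one place: chloro in place of fluoro on an aromatic carbon. For the measured compounds named here, no measured pair shows this change, so the step is expected to be small, in either direction, and probably not beyond the scatter. The expected step from compound 2 to compound 4 is a 1.1-fold lower number from compound 2 to compound 4 (0.04 log units; within the scatter). For compound 4 the estimate in this assay is 300 nM, within a range from 120 nM to 800 nM.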

Compound 4, half-maximal inhibitory concentration: 750 nM
Estimate against measurement, compound 4: 2.5-fold (0.40 log units) below; the measured number falls inside the stated range.
By their numbers in this assay, from the lowest: compound 2; then compound 4; then compounds 3 and 1 (each within the scatter of the next).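

At this position, on the aromatic carbon ortho to a large group, the assay distinguishes between the two halogens: in this assay chloro in place of fluoro gives a 2.3-fold higher number from compound 2 to compound 4 (0.36 log units; beyond the scatter) and so a modest step. For the compounds shown here, this is the first single-place comparison, and it favours the 2-fluorophenyl over the 2-chlorophenyl in this core. No measurement at hand accounts for the step.

The compounds shown leave open how a methyl group, a methoxy group or an amine would read at this position. On these data alone, whether the same change gives a similar step on another core also remains open.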